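Amide substituent variation in a sigma-binding series

The compounds below may be only part of what the source reports. "The series", "measured", "known", "first", "only" and "open" are said of these compounds alone.

Compound 1 `Fc1ccc(CN2CCC(NCCSC(c3ccc(F)cc3)c3ccc(F)cc3)CC2)cc1` gives 13.3 nM in an assay on membranes from Cortex for displacement of a labelled ligand from Sigma non-opioid intracellular receptor 1 (Cavia porcellus), read by scintillation counting, with a stated time of 120 min; on this read-out higher numbers stand for weaker inhibition and lower numbers for stronger inhibition.
Compound 2 `O=C(C1CC1)N1CCC(NCCSC(c2ccc(F)cc2)c2ccc(F)cc2)CC1` gives 46.4 nM in this assay.

Within the data shown here, compound 2 stands at the higher of the two numbers; the only measured step, a 3.5-fold higher number from compound 1 to compound 2 (0.54 log units; beyond the scatter), replaces the whole substituent on the ring nitrogen. Compound 3 `O=C(c1ccccc1F)N1CCC(NCCSC(c2ccc(F)cc2)c2ccc(F)cc2)CC1` differs from compound 2 by 2-fluorophenyl in place of cyclopropyl on a carbonyl carbon. Among the measured compounds shown here, no measured step alters the group on the carbonyl carbon, so the single step gives only a rough sense of scale; a change within the scatter, or a small move toward lower numbers, seems the most defensible reading. For compound 3 a step of about a 1.5-fold lower number from compound 2 to compound 3 (0.19 log units; within the scatter) is expected. Compound 3 is estimated at 30 nM, with a range from 8 nM to 120 nM.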

Compound 3, inhibition constant: 3.57 nM
The estimate for compound 3 lay 8.4-fold (0.92 log units) above the measured number; the measured number lies below the stated range.
By their numbers in this assay, from the lowest: compound 3; then compound 1; then compound 2.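

Within this assay, the group on the carbonyl carbon has a large influence: 2-fluorophenyl in place of cyclopropyl gives the largest step so far (a 13-fold lower number from compound 2 to compound 3 (1.11 log units; beyond the scatter)). The amide linkage therefore does not by itself give higher numbers than the benzyl amine, since (2-fluorophenyl)carbonyl in place of 4-fluorobenzyl reverses the direction seen with cyclopropylcarbonyl (a 3.7-fold lower number from compound 1 to compound 3 (0.57 log units; beyond the scatter)). No available evidence bears on the origin of these steps.

Open, going by these compounds, is whether plain phenyl on the carbonyl carbon would hold the number of compound 3. Also open, on these data alone, is how 4-fluorophenyl there would compare.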